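The source may report more compounds than this note shows. Statements on the series, on what has been measured and on what is new or still open speak of the compounds shown alone.

Measured in a functional assay on FaDu cells (Homo sapiens) for cytotoxicity, read by MTT assay, with a stated time of 72 h; a lower number here means that less compound is tolerated, a higher number that more compound is tolerated:
compound 1 `CCOc1ccc(NC(=O)C(=O)c2cn(C(C)C)c3ccccc23)cn1` gives 175 nM
compound 2 `COc1ccc(NC(=O)C(=O)c2cn(C(C)C)c3ccccc23)cn1` gives 85 nM
compound 3 `CC(C)Oc1ccc(NC(=O)C(=O)c2cn(C(C)C)c3ccccc23)cn1` gives 408 nM

Compound 3 stands highest of the three (408 nM) in this assay, so it is the one for which the most compound is tolerated.

In compound 4 `CC(C)n1cc(C(=O)C(=O)Nc2ccc(C(F)(F)F)nc2)c2ccccc21` the ether group goes: trifluoromethyl in place of isopropoxy on an aromatic carbon.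

Within the data shown here, three measured steps bear on this, all modest and all beyond the scatter: (a 2.1-fold lower number from compound 1 to compound 2 (0.31 log units; beyond the scatter)), (a 2.3-fold higher number from compound 1 to compound 3 (0.37 log units; beyond the scatter)) and (a 4.8-fold higher number from compound 2 to compound 3 (0.68 log units; beyond the scatter)). Across these three compounds the number rises as the chain on the oxygen grows, and none of them goes against this. All three steps change only that chain, and none removes the oxygen, so they are a loose guide for the new group. Among the measured compounds shown here, no measured compound carries trifluoromethyl.

A modest step to a lower number is expected, with the direction uncertain. The step expected is (a 2.0-fold lower number from compound 3 to compound 4 (0.31 log units; beyond the scatter)). For compound 4 the estimate is 200 nM within an expected range of 60 nM to 650 nM in this series.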

Compound 4, concentration lethal to 50% of the cells: > 10000 nM
Compound 4: only a limit was reported; the forecaster's own chance of this, stated with the estimate: 3%; middle value at least 50-fold (1.69 log units) from the limit.
By their numbers in this assay, from the lowest: compound 2; then compound 1; then compound 3. At a limit, above all of these: compound 4.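

In this assay compound 4 gives > 10000 nM and this is a limit of the assay, not a number. On this aromatic carbon, next to the ring nitrogen and para to a large group, trifluoromethyl in place of an oxygen-linked chain gives large steps (an at least 24-fold higher number from compound 3 to compound 4 (1.38 log units; beyond the scatter)) (an at least 110-fold higher number from compound 2 to compound 4 (2.07 log units; beyond the scatter)) (an at least 57-fold higher number from compound 1 to compound 4 (1.75 log units; beyond the scatter)), whereas changing the chain on the oxygen gave only modest ones. That limit stands alone among the compounds shown: the limit of > 10000 nM in this assay, at which 1 of the 4 values shown sits.

The compounds shown do not separate the loss of the ether oxygen from the arrival of the fluorines; an ethyl group or a trifluoromethoxy group on the same carbon would bear on that. Going by these compounds, whether the number keeps rising with a longer chain on the oxygen, such as butoxy, also stays open.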